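Shortening the ester linker on a weakly active branched ester

The compounds below may be only part of what the source reports. "The series", "measured", "known", "first", "only" and "open" are said of these compounds alone.

Compound 2 `CCCC(CCC)C(=O)OCCCOC(=O)c1ccc(C(=O)Nc2ccc3c(c2)C(C)(C)CCC3(C)C)cc1`: 835000 nM
Compound 1 `CCCC(=O)OCCCOC(=O)c1ccc(C(=O)Nc2ccc3c(c2)C(C)(C)CCC3(C)C)cc1`: 2990 nM

In a functional assay on HL-60 cells (Homo sapiens) for inhibition, read by MTT assay, with a stated time of 48 h (on this read-out lower numbers stand for stronger inhibition and higher numbers for weaker inhibition), compound 2 gives the highest number of the two measured compounds, with compound 1 giving a far lower one, a step of a 280-fold higher number from compound 1 to compound 2 (2.45 log units; beyond the scatter). Compound 3 `CCCC(CCC)C(=O)OCCOC(=O)c1ccc(C(=O)Nc2ccc3c(c2)C(C)(C)CCC3(C)C)cc1` differs from compound 2 by ((1-propylbutyl)carbonyl)oxy in place of (((1-propylbutyl)carbonyl)oxy)methyl on a saturated chain carbon, two bonds along the chain from an oxygen next to a carbonyl group. For the measured compounds named here, no measured step touches this linker change; the one measured step concerns only the acyl group, so it offers no guide. Compound 3 is therefore expected to show about no change, a 1.2-fold lower number from compound 2 to compound 3 (0.08 log units; within the scatter), and is estimated at 700000 nM (range 150000 nM to 3000000 nM).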

Compound 3, half-maximal inhibitory concentration: 256000 nM
Estimate against measurement, compound 3: 2.7-fold (0.44 log units) above; low and high end bracket the measured number.
By their numbers in this assay, from the lowest: compound 1; then compound 3; then compound 2.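

In this assay the linker position does respond to change: ((1-propylbutyl)carbonyl)oxy in place of (((1-propylbutyl)carbonyl)oxy)methyl gives a 3.3-fold lower number from compound 2 to compound 3 (0.51 log units; beyond the scatter) and so a modest gain in inhibition. The shorter linker does not close the gap to the propyl ester, with an 86-fold higher number from compound 1 to compound 3 (1.93 log units; beyond the scatter) remaining, although that comparison changes the acyl group and the linker together. No available evidence accounts for either step.

From the compounds shown here alone, whether the propyl ester would also gain from the shorter linker stays open. So does the effect of a longer chain or an amine at this position.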